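From phenethyl to 4-chlorophenyl on a sulfur

The source may report more compounds than this note shows. Statements on the series, on what has been measured and on what is new or still open speak of the compounds shown alone.

compound 1 `CCc1ccc(SCc2ccc(C(=O)Nc3ccccc3N)cc2)cc1`: 53.6%
compound 2 `Cc1ccc(SCc2ccc(C(=O)Nc3ccccc3N)cc2)cc1`: 40.5%
compound 3 `Nc1ccccc1NC(=O)c1ccc(CSCCc2ccccc2)cc1`: 44.9%

All three values come from a functional assay on A549 cells (Homo sapiens) for inhibition, read by CCK-8 assay, with a stated time of 72 h, tested at 2 uM; a lower number here means less inhibition of growth, a higher number more inhibition of growth at the concentration tested. Compound 3 cannot be told apart from either of the other two, as the steps show: a number 8.7 percentage points lower from compound 1 to compound 3 (within the scatter) and a number 4.4 percentage points higher from compound 2 to compound 3 (within the scatter). Going by the values given here, the only step beyond the scatter is a number 13.1 percentage points lower from compound 1 to compound 2 (beyond the scatter).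

The next compound is compound 4 `Nc1ccccc1NC(=O)c1ccc(CSc2ccc(Cl)cc2)cc1`, with 4-chlorophenyl in place of phenethyl on a sulfur. The two steps that bear on this change most directly are those that put phenethyl in place of a substituted phenyl on that same sulfur. Both stayed within the scatter, so swapping between these two kinds of group has not yet moved the number measurably. Among the compounds with values here, still, the gap between compound 1 and compound 2 shows that a small change on that phenyl can exceed the scatter, and no chlorine-bearing compound has been measured. A wide range is therefore warranted, without a clear direction. The expected change is a number 2.1 percentage points higher from compound 3 to compound 4 (within the scatter), which would be no step beyond the scatter. In this assay, compound 4 is estimated at 47%, with an expected range from 35% to 59%.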

Compound 4, percent growth inhibition at one concentration: 47.3%
Compound 4: middle estimate off by 0.3 percentage points, on the low side; the measured number falls inside the stated range.
By their numbers in this assay, from the lowest: compounds 2, 3, 4 and 1 (each within the scatter of the next, the first and the last beyond it).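

In this assay, putting 4-chlorophenyl in place of phenethyl on a sulfur whose other neighbour is a saturated chain carbon gives a further swap at this position that stays inside the scatter (a number 2.4 percentage points higher from compound 3 to compound 4 (within the scatter)), so phenethyl and all three substituted phenyl groups now rest on comparable readings, apart from the one gap between the methyl and ethyl compounds. The substituent on the phenyl adds a sharper point: chloro in place of methyl on an aromatic carbon gives a number 6.8 percentage points higher from compound 2 to compound 4 (within the scatter) and chloro in place of ethyl on an aromatic carbon gives a number 6.3 percentage points lower from compound 1 to compound 4 (within the scatter), so chloro cannot be told apart from either alkyl group, even though methyl and ethyl differ from each other beyond the scatter. No measurement is at hand that would explain any of these numbers.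

On these data alone, what remains open is whether the gap between methyl and ethyl reflects a real trend, which a longer chain such as propyl on the same aromatic carbon could test. As far as these compounds go, it is also open whether a group of another kind there, such as an amine or a carboxylic acid, would move the number beyond the scatter from the chloro value.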